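This account rests on a few compounds, and the source may have more. Where it says the series, first, only, none or still open, it means among the compounds named here.

Compound 1 `COc1cc(-c2nn(-c3cccc(NC(=O)Nc4cc(C(F)(F)F)cc(C(F)(F)F)c4)c3)cc2-c2ccncc2)ccc1Cl`: in a functional assay on SF-295 cells (Homo sapiens) for inhibition, read by sulforhodamine B assay, with a stated time of 48 h (on this read-out higher numbers stand for weaker inhibition of growth and lower numbers for stronger inhibition of growth), compound 1 gives 1230 nM
Compound 2 `COc1cc(-c2nn(-c3cccc(NC(=O)Nc4ccc(Cl)c(Cl)c4)c3)cc2-c2ccncc2)ccc1Cl`: in this assay compound 2 gives 2530 nM
Compound 3 `O=C(Nc1cccc(-n2cc(-c3ccncc3)c(-c3ccc(Cl)c(O)c3)n2)c1)Nc1cc(C(F)(F)F)cc(C(F)(F)F)c1`: in this assay compound 3 gives 1650 nM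

Compound 2 stands highest of the three numbers. Its nearest neighbour is compound 3, a difference within the scatter; compound 1 lies furthest from it, a difference beyond the scatter. Within the data shown here, the only single-place step among the measured compounds is a 1.3-fold higher number from compound 1 to compound 3 (0.13 log units; within the scatter), which concerns the oxygen substituent on the other aryl ring and does not touch the urea-bound ring altered here.

Compound 4 `COc1cc(-c2nn(-c3cccc(NC(=O)Nc4ccc(Cl)c(C(F)(F)F)c4)c3)cc2-c2ccncc2)ccc1Cl` differs from compound 2 by trifluoromethyl in place of chloro on an aromatic carbon. Among the measured compounds shown here, no measured step matches this change. What can be said is that compound 1, carrying two trifluoromethyl groups on that ring, gives the lowest number, while compound 2, carrying two chloro groups, gives the highest; compound 4 carries one of each. Compound 4 is therefore expected to land between the two, a step of a 1.6-fold lower number from compound 2 to compound 4 (0.20 log units; within the scatter), an expected value of 1600 nM with a range of 800 nM to 3200 nM.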

Compound 4, concentration for total growth inhibition: 2540 nM
Compound 4: the middle estimate sits 1.6-fold (0.20 log units) below what was measured; the range from low to high includes it.
By their numbers in this assay, from the lowest: compounds 1, 3, 2 and 4 (each within the scatter of the next, the first and the last beyond it).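

In this assay, among these compounds, the step of a 1.0-fold higher number from compound 2 to compound 4 (0.00 log units; within the scatter) is the first single-place step on the urea-bound ring, which the earlier compounds could not supply. Here, on an aromatic carbon ortho to a chloro group, a trifluoromethyl group with 4 heavy atoms takes the place of a chloro group with 1, and the two compounds cannot be told apart on this read-out. No measurement shown bears on why this exchange leaves the number where it stands.

The compounds shown leave open whether a nitrile, an amine or a carboxylic acid at this place would also leave the number unmoved. They also leave open whether the same exchange would read alike on the core of compound 3, which carries a hydroxy group where compound 4 carries methoxy.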